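The source may hold more compounds than are shown below. What is called first, only, known or untested is meant among the compounds shown, and "the series" means these compounds.

Working notes on a small series in a functional assay on MCF7 cells (Homo sapiens) for cytotoxicity, tested at 125 uM; a lower number here means a stronger effect, a higher number a weaker effect of the compound at the concentration tested.

Compound 1 `O=S(=O)(Nc1nnc(SCc2ccccc2)s1)c1ccccc1` gives 80% in this assay. Compound 2 `O=S(=O)(Nc1nnc(SCc2ccc(Cl)cc2)s1)c1ccccc1` carries the change chloro in place of hydrogen on an aromatic carbon relative to compound 1, and in this assay compound 2 gives 85%; the step is a number 5 percentage points higher from compound 1 to compound 2 (within the scatter). Compound 3 `Cc1ccc(S(=O)(=O)Nc2nnc(SCc3ccccc3)s2)cc1` differs from compound 1 by methyl in place of hydrogen on an aromatic carbon, and in this assay compound 3 gives 79%; the step is a number 1 percentage points lower from compound 1 to compound 3 (within the scatter). Compound 3 thus holds the lowest of the three numbers, but its gaps to compound 1 and compound 2 are both within the scatter, so no ordering among the three is supported.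

Compound 4 `Cc1ccc(S(=O)(=O)Nc2nnc(SCc3ccc(Cl)cc3)s2)cc1` is not yet measured. It differs from compound 3 by chloro in place of hydrogen on an aromatic carbon. This is the same change as that from compound 1 to compound 2, with an identical surrounding place, made here on a core that carries a methyl in place of hydrogen as told above. Going by the values given here, the only precedent for the change, the step from compound 1 to compound 2, stayed within the scatter.

The step from compound 3 to compound 4 is therefore expected to be small, about a number 4 percentage points higher from compound 3 to compound 4 (within the scatter), because the same change gave a number 5 percentage points higher from compound 1 to compound 2 (within the scatter). For compound 4 the estimate in this assay is 83%, expected to lie between 72% and 94%. This rests on one precedent only, and a number anywhere near compound 3 would be consistent with it.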

Compound 4, a percentage reported as activity, at one concentration (the size of the read-out at that concentration, not a potency): 82%
The estimate for compound 4 lay 1 percentage points above the measured number, within the range that was stated.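

In this assay the chloro change on the core of compound 3 gives a number 3 percentage points higher from compound 3 to compound 4 (within the scatter), and it carries over from the earlier core with no difference that can be told apart: the same change on two cores in this assay, a number 5 percentage points higher (within the scatter) from compound 1 to compound 2 and a number 3 percentage points higher (within the scatter) from compound 3 to compound 4, 2 percentage points apart, within the scatter of two such steps. The methyl change, read here on the chloro-bearing pair, gives a number 3 percentage points lower from compound 2 to compound 4 (within the scatter), and it too agrees with its earlier step: the same change on two cores in this assay, a number 1 percentage points lower (within the scatter) from compound 1 to compound 3 and a number 3 percentage points lower (within the scatter) from compound 2 to compound 4, 2 percentage points apart, within the scatter of two such steps. Across these four compounds the two changes therefore behave alike on both cores, but every step stays within the scatter, so this agreement shows only that neither change has a detectable effect here, not that a real effect of either change transfers from one core to another, and it says nothing about cores beyond these.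

The compounds shown leave open whether a different group on these aromatic rings, such as an amine or a carboxylic acid, would move the number beyond the scatter. Also open, going by these compounds, is whether a longer chain in place of the benzyl would do so.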